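A triazole replaces the (4-methylbenzyl)oxy group

The compounds below may be only part of what the source reports. "The series", "measured", "known", "first", "only" and "open" are said of these compounds alone.

In a functional assay on SK-OV-3 cells (Homo sapiens) for inhibition, read by CCK-8 assay, with a stated time of 70 h (a higher number here means a weaker inhibitor, a lower number a stronger inhibitor), compound 1 `c1ccc(COc2ccc(OCCOCCNC3CCCC3)cc2)cc1` gives 24800 nM and compound 2 `Nc1ccccc1COc1ccc(OCCOCCNC2CCCC2)cc1` gives 14000 nM. Compound 3 `Cc1ccc(COc2ccc(OCCOCCNC3CCCC3)cc2)cc1` gives 17200 nM, the middle number of the three, but it lies within the scatter of both others, so no real order can be read among them.

Compound 4 `c1ncn(-c2ccc(OCCOCCNC3CCCC3)cc2)n1` differs from compound 3 as follows: 1H-1,2,4-triazol-1-yl in place of (4-methylbenzyl)oxy on an aromatic carbon. The swap sits on an aromatic carbon, para to a large group.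

The measured steps bearing on it are small edits within the leaving part of the molecule: a 1.4-fold lower number from compound 1 to compound 3 (0.16 log units; within the scatter), a 1.8-fold lower number from compound 1 to compound 2 (0.25 log units; within the scatter) and a 1.2-fold higher number from compound 2 to compound 3 (0.09 log units; within the scatter). Among the compounds with values here, none of them removes that group, so they offer only weak guidance, and the data hold no direct precedent for this swap. No step beyond the scatter is therefore expected, with only a slight lean toward a higher number. The estimated step is a 1.6-fold higher number from compound 3 to compound 4 (0.21 log units; within the scatter). For compound 4 the estimated value is 28000 nM, with an expected range of 9000 nM to 80000 nM.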

Compound 4, half-maximal inhibitory concentration: > 100000 nM
Compound 4: no number, only a limit (the forecaster's own chance of this, stated with the estimate: 20%); middle value at least 3.5-fold (0.55 log units) away from the limit.
By their numbers in this assay, from the lowest: compounds 2, 3 and 1 (each within the scatter of the next). At a limit, above all of these: compound 4.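

In this assay compound 4 has no number, only a limit of the assay: the limit of > 100000 nM in this assay, at which 1 of the 4 values shown sits. Amino and methyl edits on the leaving group had stayed within the scatter, but replacing the whole group on this aromatic carbon goes beyond it in every comparison (an at least 5.8-fold higher number from compound 3 to compound 4 (0.76 log units; beyond the scatter)) and (an at least 7.1-fold higher number from compound 2 to compound 4 (0.85 log units; beyond the scatter)) and (an at least 4.0-fold higher number from compound 1 to compound 4 (0.60 log units; beyond the scatter)). This position therefore accepts the benzyloxy group and its two substituted forms with no readable difference among them, yet the 1H-1,2,4-triazol-1-yl group does not hold the number in their range.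

The swap changes the ring, the oxygen link and the heavy-atom count together, so the data cannot say which of these matters. From the compounds shown here alone, it remains open whether a phenyl group on this carbon, or a triazole joined through a methyleneoxy link, would stay in the range of compound 1.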